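The source may hold more compounds than are shown below. What is called first, only, known or untested is meant among the compounds shown, and "the series" means these compounds.

Among the compounds with values here, compound 2, `COc1cccc(/C=N/NC(=O)c2cccnc2Nc2cccc(C(F)(F)F)c2)c1`, stands lowest of the two numbers measured so far: in a functional assay on the whole organism (strain Wistar) for inhibition, with Rattus norvegicus as the target, read by paw edema, with a stated time of 1 h, at a dose of 10 mg/kg by the intraperitoneal route (on this read-out lower numbers stand for less inhibition and higher numbers for more inhibition at the one dose given (going by the name of the read-out)), compound 2 gives 58.8%. Within the data shown here, its nearest neighbour is compound 1, `O=C(N/N=C/c1cccc(O)c1)c1cccnc1Nc1cccc(C(F)(F)F)c1`, which in this assay gives 63.8%; the single change separating the two, methyl in place of hydrogen on an oxygen on an aromatic ring, produced a number 5 percentage points lower from compound 1 to compound 2 (within the scatter). Compound 3, `O=C(N/N=C/c1ccncc1)c1cccnc1Nc1cccc(C(F)(F)F)c1`, is the next member of the series; it differs from compound 2 by pyridin-4-yl in place of 3-methoxyphenyl on a carbon with a double bond to nitrogen. Among the measured compounds shown here, no measured step touches the carbon with a double bond to nitrogen, so the only guidance is the modest movement seen between compound 1 and compound 2, which stayed inside the scatter. The exchange of 3-methoxyphenyl for pyridin-4-yl is larger than that one, but without a comparable pair the expectation for compound 3 is a step of a number 1.8 percentage points lower from compound 2 to compound 3 (within the scatter), not clearly beyond the scatter. Compound 3 is therefore estimated at 57%, with a range from 40% to 72%.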

Compound 3, a percentage reported as inhibition, in the whole organism at one dose (the size of the read-out at that dose, not a potency): 70.2%
Compound 3: the middle estimate sits 13.2 percentage points below what was measured; the range from low to high includes it.
By their numbers in this assay, from the lowest: compounds 2, 1 and 3 (each within the scatter of the next, the first and the last beyond it).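

This is the first change shown at the carbon with a double bond to nitrogen, and in this assay pyridin-4-yl in place of 3-methoxyphenyl gives a number 11.4 percentage points higher from compound 2 to compound 3 (beyond the scatter), a step that clears the scatter where the earlier change on the oxygen did not. Set against 3-hydroxyphenyl, the same group gives a number 6.4 percentage points higher from compound 1 to compound 3 (within the scatter), so the step beyond the scatter holds only against 3-methoxyphenyl, and a ring of carbon only is not ruled out at this place. Nothing given here accounts for either step.

On these data alone, it remains open whether pyridin-3-yl would read like pyridin-4-yl on this carbon. As far as these compounds go, it is also open whether a ring is needed there at all, which a methyl group or a longer alkyl chain would test.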